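A few compounds are considered here, and "the series" means these few. Any claim that something is new, unique, unknown or untested is made for them only; others in the source may bear on it.

Values in a functional assay on KYSE-410 cells (Homo sapiens) for antiproliferative activity, read by MTT assay, with a stated time of 72 h; on this read-out higher numbers stand for weaker inhibition and lower numbers for stronger inhibition:
- Compound 1 `O=C(Nc1cccc(F)c1)c1cc(=O)[nH]c2cc(F)ccc12`: > 20000 nM (a limit of the assay)
- Compound 2 `O=C(Nc1cccc(F)c1)c1cc(=O)[nH]c2cc(-c3ccc(F)cc3)ccc12`: 10300 nM

Among the compounds with values here, compound 2 holds the only actual number so far in this assay, at 10300 nM. Compound 1 sits at > 20000 nM, which is a limit and not a number, as the limit of > 20000 nM in this assay, at which 1 of the 2 values shown sits, records.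

The next compound is compound 3 `CC(=O)c1ccc(-c2ccc3c(C(=O)Nc4cccc(F)c4)cc(=O)[nH]c3c2)cc1`, which keeps the shared core and the amide of compound 2. The change is acetyl in place of fluoro on an aromatic carbon, para to a large group, so 4-fluorophenyl becomes 4-acetylphenyl.

Within the data shown here, only one measured step bears on this, and it is indirect: an at least 1.9-fold lower number from compound 1 to compound 2 (0.28 log units; that floor lies within the scatter). Among the measured compounds shown here, that step introduced the 4-fluorophenyl group, and no measured pair varies the substituent on it. With that step resting on a limit, the expectation for this assay is no shift beyond the scatter, in either direction.

The expected change is a 1.1-fold lower number from compound 2 to compound 3 (0.06 log units; within the scatter). For compound 3 the estimated value is 9000 nM, with an expected range of 3000 nM to 20000 nM.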

Compound 3, half-maximal inhibitory concentration: > 20000 nM
Compound 3 gave a limit, no number; the forecaster's own chance of this, stated with the estimate: 12%; at least 2.2-fold (0.34 log units) between middle value and limit.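

In this assay compound 3 gives > 20000 nM, which is a limit of the assay and not a number. Placing acetyl instead of fluoro on this aromatic carbon, para to a large group, gives an at least 1.9-fold higher number from compound 2 to compound 3 (0.28 log units; that floor lies within the scatter), so this first variation of the substituent on the outer ring brings no gain, while the floor of the step does not establish a loss beyond the scatter. Compound 2 remains the only compound with an actual number, and the step from compound 1 to compound 3 cannot be read, leaving most of the series resting on one ceiling: the limit of > 20000 nM in this assay, at which 2 of the 3 values shown sit.

On these data alone, how far past its limit compound 3 lies remains open, and with it whether going from 4-fluorophenyl to 4-acetylphenyl is a real loss or a shift within the usual scatter. Also open, as far as these compounds go, is whether an amine, a carboxylic acid or a longer chain at this same place would move the number in either direction.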